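Chloro substitution on the benzylidene ring of hydrazide series

This account rests on a few compounds, and the source may have more. Where it says the series, first, only, none or still open, it means among the compounds named here.

Two cores are in hand. Compound 1 `O=C(N/N=C/c1ccccc1)c1cccnc1Nc1cccc(C(F)(F)F)c1` and compound 2 `O=C(N/N=C/c1cccc(Cl)c1)c1cccnc1Nc1cccc(C(F)(F)F)c1` share one core; compound 3 `CNc1ncccc1C(=O)N/N=C/c1ccccc1` and compound 4 `CNc1ncccc1C(=O)N/N=C/c1ccc(Cl)cc1` share the other. The difference between the two cores is not broken down here. In a functional assay on the whole organism (strain Wistar) for inhibition, with Rattus norvegicus as the target, read by paw edema, with a stated time of 3 h, at a dose of 10 mg/kg by the intraperitoneal route (on this read-out lower numbers stand for less inhibition and higher numbers for more inhibition at the one dose given (going by the name of the read-out)), compound 1 gives 21.2% and compound 2 gives 55.2%. The change between them is chloro in place of hydrogen on an aromatic carbon, and it made a step of a number 34 percentage points higher from compound 1 to compound 2 (beyond the scatter). On the second core, compound 3 gives 22.7% in this assay, a value within the scatter of compound 1. Compound 4 is not yet measured.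

Going by the values given here, the change from compound 3 to compound 4 is chloro in place of hydrogen on an aromatic carbon, the same kind of change as the one from compound 1 to compound 2, though the place differs: on the first core the chloro sits meta to a large group, on the second core it sits para to a large group. Whether a chloro in this new place, on a different core, carries the same step is not shown by any measured pair; the one analogous step, from compound 1 to compound 2, is the only guide. Among the compounds with values here, the step is therefore estimated more cautiously than the measured one at a number 20.3 percentage points higher from compound 3 to compound 4 (beyond the scatter), because the earlier step of a number 34 percentage points higher from compound 1 to compound 2 (beyond the scatter) is the sole precedent and was made at a different place on a different core. Compound 4 is thus estimated at 43%, with a plausible range from 25% to 62%, in this assay.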

Compound 4, a percentage reported as inhibition, in the whole organism at one dose (the size of the read-out at that dose, not a potency): 22.4%
The estimate for compound 4 lay 20.6 percentage points above the measured number; measured number below the stated range.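

In this assay, chloro in place of hydrogen on an aromatic carbon gave a number 0.3 percentage points lower from compound 3 to compound 4 (within the scatter), so on the compounds shown the gain seen on the core of compound 1 did not carry over to the core of compound 3: the same change on two cores in this assay, a number 34 percentage points higher (beyond the scatter) from compound 1 to compound 2 and a number 0.3 percentage points lower (within the scatter) from compound 3 to compound 4, 34.3 percentage points apart, beyond the scatter of two such steps

This does not show that the core alone decides the outcome, since the chloro also sits at a different place on the two cores, para to a large group in compound 4, and no pair shown separates core from place. Nor does it show how the change behaves in general, as each core offers a single step, read at one dose and one time point, and the read-out gives the size of the effect at that dose rather than a potency.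

The compounds shown leave open whether a chloro at the place it holds in compound 2 would, on the core of compound 3, follow compound 2 or compound 4, and likewise what a chloro para to a large group would do on the core of compound 1. Also open, on these data alone, is how a fluoro, a methoxy or a carboxylic acid at these places would read on either core.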